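The source may report more compounds than this note shows. Statements on the series, on what has been measured and on what is new or still open speak of the compounds shown alone.

In an assay on isolated protein for inhibition of Amine oxidase [flavin-containing] A (Homo sapiens), read by fluorescence, with a stated time of 15 min (on this read-out lower numbers stand for stronger inhibition and higher numbers for weaker inhibition), compound 1 `COc1ccc(/C=C/c2cc(OC)cc(OC)c2/C=C/C(=O)c2cc3ccccc3oc2=O)cc1` gives 41700 nM, compound 2 `COc1ccc(/C=C/c2cc(OC)cc(OC)c2/C=C/C(=O)c2cc3ccc(Br)cc3oc2=O)cc1` gives 3010 nM, and compound 3 `COc1ccc(/C=C/c2cc(OC)cc(OC)c2/C=C/C(=O)c2cc3cc(F)ccc3oc2=O)cc1` gives 44300 nM. On these numbers compound 3 stands highest, set apart from compound 1 only within the usual scatter but from compound 2 by a 15-fold higher number from compound 2 to compound 3 (1.17 log units; beyond the scatter). Compound 4 `COc1ccc(/C=C/c2cc(OC)cc(OC)c2/C=C/C(=O)c2cc3cc(C)ccc3oc2=O)cc1` differs from compound 3 in one place: methyl in place of fluoro on an aromatic carbon. Two earlier steps bear on this change. Putting a fluoro in this place brought a 1.1-fold higher number from compound 1 to compound 3 (0.03 log units; within the scatter), whereas putting a bromo there brought a 14-fold lower number from compound 1 to compound 2 (1.14 log units; beyond the scatter). For the measured compounds named here, no measured step places a methyl there, so the outlook is uncertain. A modest move toward a lower number is expected, a 2.2-fold lower number from compound 3 to compound 4 (0.35 log units; beyond the scatter), possibly still within the scatter. Compound 4 is therefore estimated at 20000 nM, within a range from 6000 nM to 60000 nM.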

Compound 4, half-maximal inhibitory concentration: 30400 nM
Compound 4: middle estimate off by 1.5-fold (0.18 log units), on the low side; low and high end bracket the measured number.
By their numbers in this assay, from the lowest: compound 2; then compounds 4, 1 and 3 (each within the scatter of the next).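

In this assay, methyl gives a result much like fluoro and hydrogen: there is a 1.5-fold lower number from compound 3 to compound 4 (0.16 log units; within the scatter) and a 1.4-fold lower number from compound 1 to compound 4 (0.14 log units; within the scatter), both within the usual scatter. Compound 2 remains apart, with a 10-fold higher number from compound 2 to compound 4 (1.00 log units; beyond the scatter), so among these four compounds only the bromo compound stands out. No evidence is available to explain this pattern. The compounds shown leave open whether chloro or iodo would match bromo or instead give numbers like those of compound 1. They also leave open how a longer chain such as ethyl, or a methoxy group, would read.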